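Adding a Phenyl Group to a T-type Channel Inhibitor

A few compounds are considered here, and "the series" means these few. Any claim that something is new, unique, unknown or untested is made for them only; others in the source may bear on it.

Compound 1, `CN(C)CCCCCSC1=Nc2ccccc2C(CC(=O)NCc2ccccc2)N1c1ccc(-c2ccccc2)cc1`: 7770 nM
Compound 2, `O=C(CC1c2ccccc2N=C(SCCCCCN2CCCC2)N1c1ccccc1)NCc1ccccc1`: 77000 nM

In an assay on cells for inhibition of Voltage-dependent T-type calcium channel subunit alpha-1G (Homo sapiens), read by patch clamp (a lower number here means a stronger inhibitor, a higher number a weaker inhibitor), compound 1 gives 7770 nM, while compound 2 gives 77000 nM, the higher of the two numbers; the gap between them is beyond the usual scatter. The two compounds differ in more than one place, so their values alone are compared here. Compound 3, `O=C(CC1c2ccccc2N=C(SCCCCCN2CCCC2)N1c1ccc(-c2ccccc2)cc1)NCc1ccccc1`, has not yet been measured. It arises from compound 2 by phenyl in place of hydrogen on an aromatic carbon, the rest of the structure of compound 2 being kept. Compound 1 carries this same phenyl and shows the lower number in this assay, so the step is expected to move downward, a 6.4-fold lower number from compound 2 to compound 3 (0.81 log units; beyond the scatter), beyond the scatter. Compound 3 is therefore expected to give about 12000 nM in this assay, with a range from 3500 nM to 40000 nM.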

Compound 3, half-maximal inhibitory concentration: 660 nM
Compound 3: middle estimate off by 18-fold (1.26 log units), on the high side; measured number outside the range, below it.
By their numbers in this assay, from the lowest: compound 3; then compound 1; then compound 2.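

In this assay, the phenyl in place of hydrogen on an aromatic carbon, para to a large group, proves a large change on its own, with a 120-fold lower number from compound 2 to compound 3 (2.07 log units; beyond the scatter) seen while the rest of compound 2 is kept. The earlier pair differed in more than one place and could not show this, nor could it show that the amine also matters: with the 4-phenylphenyl group held constant, pyrrolidin-1-yl in place of dimethylamino comes with a 12-fold lower number from compound 1 to compound 3 (1.07 log units; beyond the scatter) in the same assay. Nothing given here bears on why either change has the size it has.

The compounds shown leave open whether a smaller group such as methyl, or a pyridine ring, would serve at the same place as the added phenyl. They also leave open how a shorter chain to the pyrrolidine or a piperidine in its place would read.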